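Swapping the oxadiazole ring on a sulfoxide-bearing biphenyl

The source may report more compounds than this note shows. Statements on the series, on what has been measured and on what is new or still open speak of the compounds shown alone.

Measured compounds:
compound 1 `[O-][S+](c1ccccc1)c1ccccc1-c1n[nH]c(=S)o1` — 40.9%
compound 2 `O=S(=O)(c1ccccc1)c1ccccc1-c1n[nH]c(=S)o1` — 41.9%

Of the compounds shown here, two have been tested so far. In a functional assay on the whole organism (strain NMRI) for inhibition, with Mus musculus as the target, in the formalin test, with a stated time of 30 min, at a dose of 30 umol/kg by the intraperitoneal route (a lower number here means less inhibition, a higher number more inhibition at the dose given (going by the name of the read-out)), compound 1 gives 40.9%, and in the same test compound 2 gives 41.9%. The two values sit within the usual scatter of each other, so compound 1 stands alongside compound 2 rather than apart from it; no step beyond the scatter has been established between them.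

Compound 3 `Nc1nnc(-c2ccccc2[S+]([O-])c2ccccc2)o1` has not yet been measured. Compared with compound 1 it carries a different ring: a group of 6 heavy atoms (2 carbon, 3 nitrogen, 1 oxygen; one five-membered aromatic ring with 3 hetero atoms) in place of a group of 6 heavy atoms (2 carbon, 2 nitrogen, 1 oxygen, 1 sulfur; one five-membered aromatic ring with 3 hetero atoms), on an aromatic carbon. The new group is a 5-amino-1,3,4-oxadiazol-2-yl, sitting on an aromatic carbon of a six-membered aromatic ring of carbon only. Among the compounds with values here, nothing measured here speaks to this exchange, so no step is known for it.

The expectation for compound 3 is a step from compound 1 of a number 5.9 percentage points lower from compound 1 to compound 3 (within the scatter), small and not clearly beyond the scatter. Compound 3 is therefore estimated at 35%, within a range from 15% to 55%.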

Compound 3, a percentage reported as inhibition, in the whole organism at one dose (the size of the read-out at that dose, not a potency): 29.4%
The estimate for compound 3 lay 5.6 percentage points above the measured number; the measured number falls inside the stated range.
By their numbers in this assay, from the lowest: compound 3; then compounds 1 and 2 (each within the scatter of the next).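

In this assay the ring exchange gives a number 11.5 percentage points lower from compound 1 to compound 3 (beyond the scatter) and so shows that this position on the aromatic carbon responds to the identity of the ring, a point that the earlier pair of compounds could not address. The step is modest, yet it arises between two groups of 6 heavy atoms, each a five-membered aromatic ring with 3 hetero atoms, so the inhibition at this dose does not depend on ring size and heavy-atom count alone. Nothing measured on these compounds explains the step, and its cause remains unknown.

The compounds shown leave open whether the same ring exchange would give a similar step on the core of compound 2, which carries a sulfone in place of the sulfoxide. They also leave open whether the step follows from the amine itself or from the rest of the ring, a question that a methylamino group or a methyl group on the same oxadiazole would bear on, and how any of these compounds would behave at other doses.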